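The source may report more compounds than this note shows. Statements on the series, on what has been measured and on what is new or still open speak of the compounds shown alone.

Among the compounds measured so far in an ADME assay on microsomes from liver (Rattus norvegicus) for metabolic stability, read by LC-MS, with a stated time of 15 min, tested at 1 uM (a higher number here means that more of the compound is left, a lower number that less of the compound is left), compound 1 (`Cc1cc(F)cnc1N1CCN(C(=O)CCCc2cccc3ncoc23)[C@@H](C)C1`) gives 0% and holds the lower of the two available numbers. Compound 2 (`O=C(CCS(=O)(=O)c1cccc2ncsc12)N1CCN(c2ccc(Cl)cn2)CC1`) stands at 31% and so lies higher by a margin beyond the scatter. Compound 3 (`N#Cc1cc(N2CCN(C(=O)CCS(=O)(=O)c3cccc4ncsc34)CC2)ccn1`) is recorded as "not determined" (no result reported) and offers nothing to compare.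

Compound 4 (`Cc1cc(F)cnc1N1CCN(C(=O)CCCc2cccc3nc(N)sc23)[C@@H](C)C1`) has yet to be measured. It keeps the core of compound 1 and differs in one group. The change is 2-amino-1,3-benzothiazol-7-yl in place of 1,3-benzoxazol-7-yl on a saturated chain carbon, three bonds along the chain from a carbonyl carbon and it sits on a saturated chain carbon, three bonds along the chain from a carbonyl carbon.

Among the compounds with values here, no measured pair of compounds tests this swap directly, so any expectation remains loose. Since compound 1 sits at 0% in this assay the number has no room to fall. A modest rise is expected, estimated as a number 10 percentage points higher from compound 1 to compound 4 (within the scatter) and possibly not beyond the scatter. The estimated value for compound 4 is 10% with an expected range from 0% to 35% at the upper end.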

Compound 4, percent of the compound remaining: 3.7%
Compound 4: middle estimate off by 6.3 percentage points, on the high side; the range from low to high includes it.
By their numbers in this assay, from the lowest: compounds 1 and 4 (each within the scatter of the next); then compound 2.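

In this assay, within the data shown here, the pair of compound 1 and compound 4 offers the first comparison of two compounds that differ in one place, on a saturated chain carbon, three bonds along the chain from a carbonyl carbon. Putting 2-amino-1,3-benzothiazol-7-yl in place of 1,3-benzoxazol-7-yl gives a number 3.7 percentage points higher from compound 1 to compound 4 (within the scatter), so this exchange of one two-ring group for another, with its added hydrogen-bond donor, leaves the number within the usual scatter on this core. No measurement at hand explains this result.

With compound 1 at 0%, any further fall at this position could not show on this scale. The effects of the ring sulfur and the amine also remain unseparated, and 2-amino-1,3-benzoxazol-7-yl, which carries the amine on the original ring, would be one way to tell them apart.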